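Compound 3 to compound 4: a step among limits

The compounds below may be only part of what the source reports. "The series", "measured", "known", "first", "only" and "open" are said of these compounds alone.

Measured in a functional assay on SK-BR-3 cells (Homo sapiens) for antiproliferative activity, read by MTT assay, with a stated time of 72 h; a lower number here means a stronger inhibitor, a higher number a weaker inhibitor:
Compound 1 `C/C=C1/[C@H](O[C@@H]2O[C@H](CO)[C@@H](O)[C@H](O)[C@H]2O)OC=C(C(=O)OC)[C@H]1CC(=O)OCc1ccco1`: > 15000 nM (a limit)
Compound 2 `C=C(C)CCOC(=O)C[C@@H]1C(C(=O)OC)=CO[C@@H](O[C@@H]2O[C@H](CO)[C@@H](O)[C@H](O)[C@H]2O)/C1=C/C`: > 15000 nM (a limit)
Compound 3 `C/C=C1/[C@H](O[C@@H]2O[C@H](CO)[C@@H](O)[C@H](O)[C@H]2O)OC=C(C(=O)OC)[C@H]1CC(=O)OCCc1ccc([N+](=O)[O-])cc1`: > 20000 nM (a limit)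

Compound 3 stands only at a limit, > 20000 nM, and so has no number of its own. The other two compounds sit at the limit of > 15000 nM in this assay, at which 2 of the 3 values shown sit.

Compound 4 `C/C=C1/[C@H](O[C@@H]2O[C@H](CO)[C@@H](O)[C@H](O)[C@H]2O)OC=C(C(=O)OC)[C@H]1CC(=O)OCc1ccccc1` differs from compound 3 by one change: phenyl in place of 4-nitrobenzyl on a saturated chain carbon bound to an oxygen next to a carbonyl group. In words, this is phenyl in place of 4-nitrobenzyl on a saturated chain carbon bound to an oxygen next to a carbonyl group.

Two measured changes at this place bear on it: a step that the two limits leave unreadable from compound 1 to compound 3 and a step that the two limits leave unreadable from compound 2 to compound 3. Neither has a readable size, so no group at this place has yet given a number in this assay. On those two steps, no step beyond the scatter is expected in either direction, and the estimated change is a number no higher from compound 3 to compound 4 (the limit leaves the size open). A further limit is the likely report. For compound 4 the estimated value is 20000 nM, with an expected range of 12000 nM to 40000 nM.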

Compound 4, half-maximal inhibitory concentration: > 15000 nM
Compound 4: no number, only a limit; the forecaster's own chance of this, stated with the estimate: 85%; the middle value lies beyond the limit too.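

In this assay, compound 4 gives only a limit, as do compound 1, compound 2 and compound 3, so none of the steps among these four compounds can be read. The compounds shown leave open what number any of them would reach and whether changing the group at this place alters it.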